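From compound 2 to compound 3: a methoxy group added

A few compounds are considered here, and "the series" means these few. Any claim that something is new, unique, unknown or untested is made for them only; others in the source may bear on it.

In an ADME assay on liver (Rattus norvegicus) for metabolic stability, using microsomes (a higher number here means that the compound lasts longer, a lower number that the compound disappears faster), compound 2 `CN1Cc2cc(ccc2S(=O)(=O)C2CC2)NC(=O)CCc2cccc(c2)[C@@H](Nc2ccc3c(N)ncc(F)c3c2)C1=O` gives 0.55 h and compound 1 `CN1Cc2cc(ccc2S(=O)(=O)C2CC2)NC(=O)CCc2cc(ccc2OCC2CC2)[C@@H](Nc2ccc3c(N)ncc(F)c3c2)C1=O` gives 0.383 h, so these two values lie within the scatter of each other. Compound 3 `COc1cc2cc(c1)[C@@H](Nc1ccc3c(N)ncc(F)c3c1)C(=O)N(C)Cc1cc(ccc1S(=O)(=O)C1CC1)NC(=O)CC2` shares the core of compound 2 and differs from it in one place: methoxy in place of hydrogen on an aromatic carbon. Among the measured compounds shown here, only one measured step bears on this change, and only loosely, as it concerns a different group: hydrogen in place of cyclopropylmethoxy on an aromatic carbon. Since a 1.4-fold higher number from compound 1 to compound 2 (0.16 log units; within the scatter) stays within the scatter, no step beyond the scatter is expected in this assay for the methoxy group. The expected step is a 1.2-fold lower number from compound 2 to compound 3 (0.09 log units; within the scatter). For compound 3 the estimated half-life is 0.45 h, with an expected range from 0.22 h to 0.9 h.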

Compound 3, half-life: 0.767 h
The estimate for compound 3 lay 1.7-fold (0.23 log units) below the measured number; the range from low to high includes it.
By their numbers in this assay, from the lowest: compounds 1, 2 and 3 (each within the scatter of the next).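

In this assay, the step to methoxy on this aromatic carbon, meta to two fused rings, is a 1.4-fold higher number from compound 2 to compound 3 (0.14 log units; within the scatter), so this change gives no shift that can be told from repeat scatter. Among the compounds shown here, the earlier step, a 1.4-fold higher number from compound 1 to compound 2 (0.16 log units; within the scatter), concerned cyclopropylmethoxy, so this is the first reading for methoxy in place of hydrogen at this position, and it too stays within the scatter. The data offer no measurement that could explain the small step, and nothing here bears on its cause.

Going by these compounds, whether a different group at this same place, such as an amine, a carboxylic acid or a longer alkoxy chain, would move the half-life beyond the scatter remains open. The three compounds shown cannot settle how far this position tolerates change in this assay.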